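The source may hold more compounds than are shown below. What is called first, only, known or untested is meant among the compounds shown, and "the series" means these compounds.

Measured compounds:
Compound 1 `CCCCNC(=O)Nc1cccc2c1CN(C)CC2c1ccccc1`: in a functional assay on the whole organism for inhibition, with Mus musculus as the target (a higher number here means that more compound is needed for the effect, a lower number that less compound is needed), compound 1 gives 23 mg/kg.
Compound 2 `CCCCNC(=O)Nc1cccc2c1CN(C)CC2c1ccc(Cl)cc1`: in this assay compound 2 gives 15 mg/kg.
Compound 3 `CCOC(=O)Nc1cccc2c1CN(C)CC2c1ccccc1`: in this assay compound 3 gives about 4 mg/kg.

Compound 4 `CCOC(=O)Nc1cccc2c1CN(C)CC2c1ccc(Cl)cc1` has not yet been measured in this assay.

Two changes run through the series. The first is ethoxy in place of butylamino on a carbonyl carbon; this is how the core of compound 3 differs from the core of compound 1, and it made a 5.8-fold lower number from compound 1 to compound 3 (0.76 log units; beyond the scatter). The second is chloro in place of hydrogen on an aromatic carbon, which made a 1.5-fold lower number from compound 1 to compound 2 (0.19 log units; within the scatter), a step that does not stand out from repeat measurements.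

The same change, chloro in place of hydrogen on an aromatic carbon, separates compound 3 from compound 4: chloro in place of hydrogen on an aromatic carbon. The place lines for the two occurrences read the same, so the change in compound 4 is taken as the same change already seen between compound 1 and compound 2. It occurs twice in all among the compounds here, once measured and once not.

For compound 4 in this assay the step is expected to be a 1.3-fold lower number from compound 3 to compound 4 (0.12 log units; within the scatter), set beside the earlier 1.5-fold lower number from compound 1 to compound 2 (0.19 log units; within the scatter); the expectation rests on that single measured occurrence, which was small, and on compound 3 standing at about 4 mg/kg. Among the measured compounds shown here, compound 4 is therefore estimated at 3 mg/kg, with the range 1.5 mg/kg to 8 mg/kg allowing for the scatter of this kind of measurement and for only one prior example of the change.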

Compound 4, dose for half-maximal effect: 0.6 mg/kg
For compound 4 the middle estimate is 5.0-fold (0.70 log units) above the measured one; the whole stated range lies above it.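

In this assay, chloro in place of hydrogen on an aromatic carbon gave a 6.7-fold lower number from compound 3 to compound 4 (0.82 log units; beyond the scatter) on the core carrying ethoxy, so the small step seen on the core carrying butylamino did not carry over at the same size: the same change on two cores in this assay, a 1.5-fold lower number (0.19 log units; within the scatter) from compound 1 to compound 2 and a 6.7-fold lower number (0.82 log units; beyond the scatter) from compound 3 to compound 4, 4.3-fold (0.64 log units) apart, beyond the scatter of two such steps

Read the other way, ethoxy in place of butylamino gave a 25-fold lower number from compound 2 to compound 4 (1.40 log units; beyond the scatter) with the 4-chlorophenyl present, and this step also differs from its counterpart on the phenyl compounds: the same change on two cores in this assay, a 5.8-fold lower number (0.76 log units; beyond the scatter) from compound 1 to compound 3 and a 25-fold lower number (1.40 log units; beyond the scatter) from compound 2 to compound 4, 4.3-fold (0.64 log units) apart, beyond the scatter of two such steps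

The two changes are therefore not additive in this set of compounds, and each step pointed to a lower number on both cores, but this rests on a single square of compounds, with one pair for each comparison, and does not show why the steps differ or how general the dependence is.

The compounds shown leave open whether the larger step belongs to chloro itself or would also appear with fluoro, bromo or methoxy at the same place on the phenyl. They also leave open whether the same dependence holds when ethoxy gives way to methoxy, a longer alkoxy chain or a shorter alkylamino chain on the carbonyl carbon.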